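Swapping the aryl group on the piperazine nitrogen

The source may report more compounds than this note shows. Statements on the series, on what has been measured and on what is new or still open speak of the compounds shown alone.

Three compounds share one core and differ only in the aromatic ring on an amine nitrogen in a ring. In a functional assay on HeLa cells (Homo sapiens) for antiproliferative activity, read by CCK-8 assay, with a stated time of 72 h, tested at 8 uM (a higher number here means a stronger effect of the compound at the concentration tested, a lower number a weaker effect), compound 1 `Nc1ccccc1NC(=O)c1ccc(CSC(=S)N2CCN(c3ncccn3)CC2)cc1` gives 73.9%, compound 2 `Nc1ccccc1NC(=O)c1ccc(CSC(=S)N2CCN(c3ccccc3F)CC2)cc1` gives 59.2%, and compound 3 `Nc1ccccc1NC(=O)c1ccc(CSC(=S)N2CCN(c3ccncc3)CC2)cc1` gives 77.4%. Compound 3 and compound 1 lie within the scatter of each other, as the step of a number 3.5 percentage points higher from compound 1 to compound 3 (within the scatter) shows, while compound 3 stands beyond the scatter above compound 2, by a number 18.2 percentage points higher from compound 2 to compound 3 (beyond the scatter); the step of a number 14.7 percentage points lower from compound 1 to compound 2 (beyond the scatter) points the same way.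

Compound 4 `Nc1ccccc1NC(=O)c1ccc(CSC(=S)N2CCN(c3cnccn3)CC2)cc1` is not yet measured. It differs from compound 3 in one place: pyrazin-2-yl in place of pyridin-4-yl on an amine nitrogen in a ring. The step that bears most on this is a number 3.5 percentage points higher from compound 1 to compound 3 (within the scatter), where a six-membered aromatic ring with two nitrogens gave way to one with a single nitrogen without a change beyond the scatter. Only the ring of compound 2 fell away. Compound 4 is therefore expected to move by about a number 3.4 percentage points lower from compound 3 to compound 4 (within the scatter) in this assay, that is, no step beyond the scatter. Compound 4 is estimated at 74%, with a range from 60% to 86%.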

Compound 4, a percentage reported as inhibition, at one concentration (the size of the read-out at that concentration, not a potency): 76.9%
For compound 4 the middle estimate is 2.9 percentage points below the measured one; measured number inside the range.
By their numbers in this assay, from the lowest: compound 2; then compounds 1, 4 and 3 (each within the scatter of the next).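

In this assay, the step of a number 0.5 percentage points lower from compound 3 to compound 4 (within the scatter) adds a third nitrogen-bearing ring to the group of compounds that cannot be told apart, and the step of a number 3 percentage points higher from compound 1 to compound 4 (within the scatter) shows that the two rings with 2 hetero atoms cannot be told apart either, although their nitrogens are arranged differently. Only the 2-fluorophenyl ring stands apart, as the step of a number 17.7 percentage points higher from compound 2 to compound 4 (beyond the scatter) confirms, so among these four compounds compound 2 is the sole exception to a shared level. No measurement here gives a reason for this result. The compounds shown leave open whether an unsubstituted phenyl ring would fall with compound 2 or stand with the other three, so the fluorine and the carbon-only ring cannot be separated. On these data alone, how a non-aromatic group such as methyl or acetyl would behave at this nitrogen also remains open.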